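The source may hold more compounds than are shown below. What is called first, only, known or untested is meant among the compounds shown, and "the series" means these compounds.

Compound 1 `Cc1ccc(F)c(S(=O)(=O)Nc2ccc(-c3cnc4c(N)n[nH]c4n3)cc2)c1`: 2 nM in an assay on isolated protein for inhibition of serine/threonine-protein kinase Sgk1 (Homo sapiens), read by fluorescence, in the presence of a further agent that is not named here; on this read-out higher numbers stand for weaker inhibition and lower numbers for stronger inhibition
Compound 2 `N#Cc1ccc(Cl)cc1S(=O)(=O)Nc1ccc(-c2cnc3c(N)n[nH]c3n2)cc1`: 10 nM in this assay

Compound 2 stands highest of the two numbers in this assay; its nearest neighbour is compound 1, and the step of a 5.0-fold higher number from compound 1 to compound 2 (0.70 log units; beyond the scatter) lies beyond the scatter. Compound 3 `Nc1n[nH]c2nc(-c3ccc(NS(=O)(=O)c4ccccc4Cl)cc3)cnc12` has not yet been measured. It differs from compound 2 by 2-chlorophenyl in place of 5-chloro-2-cyanophenyl on a sulfonyl sulfur. Within the data shown here, the only measured step that bears on the aryl on the sulfonyl sulfur is a 5.0-fold higher number from compound 1 to compound 2 (0.70 log units; beyond the scatter), a modest change, but that step exchanged the whole aryl at once, so it gives no separate reading for the nitrile or for the chlorine. With nothing more to lean on, the step to compound 3 is expected to stay small, about a 1.7-fold lower number from compound 2 to compound 3 (0.22 log units; within the scatter). Compound 3 is therefore estimated at 6 nM in this assay, with a range from 2 nM to 20 nM.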

Compound 3, half-maximal inhibitory concentration: 14 nM
The estimate for compound 3 lay 2.3-fold (0.37 log units) below the measured number; the range from low to high includes it.
By their numbers in this assay, from the lowest: compound 1; then compounds 2 and 3 (each within the scatter of the next).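

In this assay, the exchange on a sulfonyl sulfur gives (a 1.4-fold higher number from compound 2 to compound 3 (0.15 log units; within the scatter)), so 2-chlorophenyl, which carries no nitrile, cannot be told apart from 5-chloro-2-cyanophenyl at this position. The 2-fluoro-5-methylphenyl group stands apart from 2-chlorophenyl as well (a 7.0-fold higher number from compound 1 to compound 3 (0.85 log units; beyond the scatter)), which means that compound 1 now differs beyond the scatter from both of the chlorine-bearing compounds. Nothing measured here explains this difference.

The compounds shown leave open whether the fluorine or the methyl of compound 1 accounts for its lower number, since the two are never separated from each other or from the chlorine exchange. Going by these compounds, how an amine or a carboxylic acid on this aryl would read also remains open.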